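The source may report more compounds than this note shows. Statements on the series, on what has been measured and on what is new or still open speak of the compounds shown alone.

In a functional assay on HepG2 cells (Homo sapiens) for antiproliferative activity, read by MTT assay, with a stated time of 48 h (a higher number here means a weaker inhibitor, a lower number a stronger inhibitor), compound 1 (`O=C(/C=C/c1c[nH]c2ccccc12)c1ccncc1`) gives 49300 nM and compound 2 (`COc1ccc(S(=O)(=O)n2cc(/C=C/C(=O)c3ccncc3)c3ccccc32)cc1`) gives 26000 nM, two numbers within the usual scatter of each other. Compound 3 (`CCCS(=O)(=O)n1cc(/C=C/C(=O)c2ccncc2)c2ccccc21`) carries propyl in place of 4-methoxyphenyl on a sulfonyl sulfur. Among the compounds with values here, no measured pair shows a change of this kind, so no known step can be carried over, and no step beyond the scatter is expected in this assay. The estimated change is a 1.2-fold higher number from compound 2 to compound 3 (0.06 log units; within the scatter). For compound 3 the expected value is 30000 nM, with an estimated range of 12000 nM to 70000 nM.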

Compound 3, half-maximal inhibitory concentration: 46200 nM
Estimate against measurement, compound 3: 1.5-fold (0.19 log units) below; the measured number falls inside the stated range.
By their numbers in this assay, from the lowest: compounds 2, 3 and 1 (each within the scatter of the next).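

In this assay, propyl in place of 4-methoxyphenyl on the sulfonyl sulfur gives a 1.8-fold higher number from compound 2 to compound 3 (0.25 log units; within the scatter) so removing the aromatic ring at this position produces no step beyond the scatter. Propylsulfonyl in place of hydrogen on the aromatic nitrogen gives a 1.1-fold lower number from compound 1 to compound 3 (0.03 log units; within the scatter) and this single change likewise stays within the scatter. No measurement bearing on these results is available. From the compounds shown here alone, whether an amine, a carboxylic acid or a chain longer than propyl on the sulfonyl sulfur would give a step beyond the scatter remains open.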